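Swapping a Fluoro for a Methoxy on the Benzyl Ring

This account rests on a few compounds, and the source may have more. Where it says the series, first, only, none or still open, it means among the compounds named here.

Measured compounds:
compound 1 `COc1ccc(N2C(=O)N(Cc3c(F)cc(F)cc3F)c3ccccc3S2(=O)=O)cc1OC` with 50.1 nM
compound 2 `COc1cc(N2C(=O)N(Cc3c(F)cc(F)cc3F)c3ccccc3S2(=O)=O)ccn1` with 398 nM
compound 3 `COc1cc(N2C(=O)N(Cc3c(F)cc(F)cc3Cl)c3ccccc3S2(=O)=O)cnc1OC` with 39.8 nM

All three share one core and were tested in an assay on isolated protein for displacement of a labelled ligand from Orexin/Hypocretin receptor type 1 (Homo sapiens), with a stated time of 90 min; a lower number here means a stronger inhibitor, a higher number a weaker inhibitor. Compound 1 stands second highest of the three numbers: compound 3 lies closest, and the two values are within the scatter of each other, so no order between them can be read. Among the measured compounds shown here, compound 2 lies furthest away, and the step of a 7.9-fold higher number from compound 1 to compound 2 (0.90 log units; beyond the scatter) is the one change here that clearly moved the number, though it sits on the ring attached to the amide-type nitrogen.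

Compound 4 `COc1ccc(N2C(=O)N(Cc3c(F)cc(F)cc3OC)c3ccccc3S2(=O)=O)cc1OC` has not yet been measured. It differs from compound 1 by methoxy in place of fluoro on an aromatic carbon, a change on the benzyl ring rather than on the amide-side ring. For the measured compounds named here, none of the measured steps touches this position, so there is no direct precedent for it. Compound 3 carries a chloro in place of one fluoro on that same ring, yet also differs elsewhere, so its value alone cannot separate the two effects.

With nothing measured at this position, the expectation for compound 4 is a step of a 1.6-fold higher number from compound 1 to compound 4 (0.20 log units; within the scatter), likely within the scatter, with a slight lean toward a weaker inhibitor. Compound 4 is therefore estimated at 80 nM, in the range 25 nM to 300 nM.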

Compound 4, inhibition constant: 63.1 nM
Estimate against measurement, compound 4: 1.3-fold (0.10 log units) above; the range from low to high includes it.
By their numbers in this assay, from the lowest: compounds 3, 1 and 4 (each within the scatter of the next); then compound 2.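

In this assay, among the compounds shown here, this is the first direct reading at this position on the benzyl ring, and it gives a 1.3-fold higher number from compound 1 to compound 4 (0.10 log units; within the scatter), so the 2,4,6-trifluorobenzyl and 2,4-difluoro-6-methoxybenzyl groups cannot be told apart here. The position therefore takes a methoxy, with two heavy atoms and one hydrogen-bond acceptor, in place of a fluoro, with one heavy atom and no acceptor, without a difference that this measurement can resolve, unlike the change on the other ring, which gave a 7.9-fold higher number from compound 1 to compound 2 (0.90 log units; beyond the scatter). Nothing shown here offers an explanation for this result.

As far as these compounds go, it remains open whether an amine, a hydroxyl group or a longer chain such as butoxy at this same place would also stay within the scatter of compound 1, or would shift the number clearly in one direction. From the compounds shown here alone, it is also open whether fluoro to methoxy on the benzyl ring would read the same with the 2-methoxypyridin-4-yl group of compound 2 in place of the 3,4-dimethoxyphenyl group.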